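Styryl sulfones: from 4-cyanophenyl to 3,4-dichlorophenyl

The source may hold more compounds than are shown below. What is called first, only, known or untested is meant among the compounds shown, and "the series" means these compounds.

Measured in a functional assay on HT-29 cells (Homo sapiens); a lower number here means a stronger inhibitor of growth, a higher number a weaker inhibitor of growth:
- compound 1 `O=S(=O)(/C=C/c1ccccc1)Cc1ccc(Nc2ncnc3ccccc23)cc1`: > 100000 nM (a limit)
- compound 2 `O=S(=O)(/C=C/c1ccc(F)cc1)Cc1ccc(Nc2ncnc3ccccc23)cc1`: 1000 nM
- compound 3 `N#Cc1ccc(/C=C/S(=O)(=O)Cc2ccc(Nc3ncnc4ccccc34)cc2)cc1`: > 100000 nM (a limit)

Compound 3 stands only at a limit, > 100000 nM. That is the limit of > 100000 nM in this assay, at which 2 of the 3 values shown sit.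

Compound 4 `O=S(=O)(/C=C/c1ccc(Cl)c(Cl)c1)Cc1ccc(Nc2ncnc3ccccc23)cc1` carries 3,4-dichlorophenyl in place of 4-cyanophenyl (3,4-dichlorophenyl in place of 4-cyanophenyl on a double-bonded chain carbon bound to a double-bonded chain carbon).

Fluoro in place of hydrogen gives an at least 100-fold lower number from compound 1 to compound 2 (2.00 log units; beyond the scatter). Cyano in place of fluoro gives an at least 100-fold higher number from compound 2 to compound 3 (2.00 log units; beyond the scatter). Cyano in place of hydrogen gives a step that the two limits leave unreadable from compound 1 to compound 3.

For the measured compounds named here, the expectation rests on compound 2 at 1000 nM, the only measured compound with a halogen on that aromatic ring. A large step to a lower number is therefore expected, though another limit remains possible. The estimated step is an at least 33-fold lower number from compound 3 to compound 4 (1.52 log units; beyond the scatter).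

For compound 4 the estimated value is 3000 nM, with an expected range of 400 nM to 50000 nM.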

Compound 4, concentration for 50% growth inhibition: 11000 nM
Compound 4: middle estimate off by 3.7-fold (0.56 log units), on the low side; measured number inside the range.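

In this assay, for the compounds shown here, compound 2 is no longer the only halogen-bearing compound to come off the limit, with an at least 9.0-fold lower number from compound 3 to compound 4 (0.95 log units; beyond the scatter) and an at least 9.0-fold lower number from compound 1 to compound 4 (0.95 log units; beyond the scatter). Both steps are bounds only, because compound 1 and compound 3 stand at a limit: the limit of > 100000 nM in this assay, at which 2 of the 4 values shown sit. The halogen-bearing rings are not interchangeable at this place, with an 11-fold higher number from compound 2 to compound 4 (1.04 log units; beyond the scatter).

From the compounds shown here alone, whether that loss goes with chlorine in place of fluorine or with the second ring substituent stays open. Going by these compounds, how a 4-chlorophenyl or a 4-aminophenyl would stand at this place also stays open.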